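The source may report more compounds than this note shows. Statements on the series, on what has been measured and on what is new or still open speak of the compounds shown alone.

Series notes. Compound 1 `ClCc1ccc(Cn2cnc3nc(Cl)nc(Cl)c32)cc1` and compound 3 `ClCc1ccccc1Cn1cnc2nc(Cl)nc(Cl)c21` share the same atoms joined differently; the difference between the two cores is not broken down here. In a functional assay on OVCAR-3 cells (Homo sapiens) for cytotoxicity, read by sulforhodamine B assay, with a stated time of 48 h (on this read-out lower numbers stand for higher toxicity in this test and higher numbers for lower toxicity in this test), compound 1 gives 2510 nM, the lowest of the three numbers, while compound 3 gives 53700 nM. Compound 2 `ClCc1ccccc1Cn1cnc2ncnc(Cl)c21` gives 8310 nM in this assay. One change has been measured once: hydrogen in place of chloro on an aromatic carbon from compound 3 to compound 2, a step of a 6.5-fold lower number from compound 3 to compound 2 (0.81 log units; beyond the scatter). Compound 4 `ClCc1ccc(Cn2cnc3ncnc(Cl)c32)cc1` carries the same change on the core of compound 1, (hydrogen in place of chloro on an aromatic carbon), and its place reads the same word for word as before. The step from compound 1 to compound 4 is expected to be a 3.6-fold lower number from compound 1 to compound 4 (0.55 log units; beyond the scatter), a lower number as in the earlier step, though perhaps smaller because compound 1 already stands at 2510 nM. The expected value for compound 4 is 700 nM, with a range from 250 nM to 2000 nM.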

Compound 4, concentration lethal to 50% of the cells: 6300 nM
Beside the measured number, compound 4's estimate is 9.0-fold (0.95 log units) below it; measured number outside the range, above it.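

In this assay, hydrogen in place of chloro on an aromatic carbon gives a 2.5-fold higher number from compound 1 to compound 4 (0.40 log units; beyond the scatter), so the change does not carry over from one core to the other, even in direction: the same change on two cores in this assay, a 6.5-fold lower number (0.81 log units; beyond the scatter) from compound 3 to compound 2 and a 2.5-fold higher number (0.40 log units; beyond the scatter) from compound 1 to compound 4, 16-fold (1.21 log units) apart, beyond the scatter of two such steps

On these two pairs, the result of the change depends on the core it sits on. They do not show which difference between the cores sets this, nor which direction the change would take on a further core.

The compounds shown leave open how an amine or a methoxy group would behave on the aromatic carbon between two ring nitrogen atoms. On these data alone, it also remains open whether either group would follow the step seen on the core of compound 1 or the one seen on the core of compound 3.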